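The source may report more compounds than this note shows. Statements on the series, on what has been measured and on what is new or still open speak of the compounds shown alone.

Compound 1 `C=CCNc1nc(N)c(C(=O)N=C(N)N)nc1Cl` carries an allylamino group on its shared core. Going by the values given here, in an assay for inhibition of acid-sensing ion channel 3 (Homo sapiens), read by patch clamp, tested at 20 uM (a higher number here means more inhibition at the concentration tested (going by the name of the read-out), a lower number less inhibition), compound 1 gives 78%, the lower of the two values measured so far. Compound 2 `NC(N)=NC(=O)c1nc(Cl)c(NCc2ccc3ccccc3c2)nc1N`, which bears a naphthylmethylamino group instead, gives 93% in this assay, a difference from compound 1 that lies beyond the usual scatter. Compound 3 `NC(N)=NC(=O)c1nc(Cl)c(Oc2ccccc2)nc1N` has not yet been measured. It differs from compound 1 in one place: phenoxy in place of allylamino on an aromatic carbon. Among the compounds with values here, only two measured values are available, and neither pair of them forms a single-change step, so the size of any change can only be guessed. Compound 2 shows that a larger substituent at this place can go together with stronger inhibition, and on that basis a small upward move, within the scatter, is expected; the step from compound 1 to compound 3 is estimated as a number 4 percentage points higher from compound 1 to compound 3 (within the scatter). Compound 3 is therefore expected to give about 82% in this assay, within a range from 62% to 95%.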

Compound 3, a percentage reported as inhibition, at one concentration (the size of the read-out at that concentration, not a potency): 90%
For compound 3 the middle estimate is 8 percentage points below the measured one; low and high end bracket the measured number.
By their numbers in this assay, from the lowest: compound 1; then compounds 3 and 2 (each within the scatter of the next).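

Replacing allylamino with phenoxy on this aromatic carbon gives, in this assay, a number 12 percentage points higher from compound 1 to compound 3 (beyond the scatter), the first single-change step available at this position. Phenoxy carries no hydrogen-bond donor and joins the shared core through oxygen, so among the compounds shown, a nitrogen link with its hydrogen is not needed for strong inhibition, as compound 3 gives 90% and compound 2, which keeps that link, gives 93%, within the scatter of each other. No measurement here explains why the change raises inhibition.

On these data alone, it remains open whether the aromatic ring, the oxygen link or both account for the step. A phenylamino group at this place would keep the ring with a nitrogen link, while a methoxy group would keep the oxygen without the ring, so each would separate these two changes.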